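The compounds below may be only part of what the source reports. "The series", "measured", "known", "first", "only" and "open" are said of these compounds alone.

Measured in a functional assay on HepG2 cells (Homo sapiens) for cytotoxicity, read by MTT assay, with a stated time of 72 h; on this read-out lower numbers stand for stronger inhibition and higher numbers for weaker inhibition:
- Compound 1 `Cc1c(C)c2c(c(C)c1OC(=O)CCC(=O)NC1CC(C)(C)N([O])C(C)(C)C1)CC[C@@](C)(CCC[C@H](C)CCC[C@H](C)CCCC(C)C)O2`: > 300000 nM (a limit)
- Compound 2 `Cc1c(C)c2c(c(C)c1OC(=O)CCC(=O)O)CCC(C)(C(=O)NC1CC(C)(C)N([O])C(C)(C)C1)O2`: > 300000 nM (a limit)

Compound 2 stands at the limit of > 300000 nM in this assay, at which 2 of the 2 values shown sit, so its > 300000 nM is a limit and not a number. Compound 3 `Cc1c(C)c2c(c(C)c1O)CCC(C)(C(=O)NC1CC(C)(C)N([O])C(C)(C)C1)O2` differs from compound 2 by hydrogen in place of (2-carboxyethyl)carbonyl on an oxygen on an aromatic ring. Among the compounds with values here, no measured pair shows this change, so the expectation rests only on the limit of compound 2. In this assay the expected direction is towards stronger inhibition, if there is any change beyond the scatter. The estimated step is an at least 1.5-fold lower number from compound 2 to compound 3 (0.17 log units; that floor lies within the scatter). For compound 3 the estimated value is 200000 nM, with an expected range of 60000 nM to 400000 nM.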

Compound 3, half-maximal inhibitory concentration: 54000 nM
Estimate against measurement, compound 3: 3.7-fold (0.57 log units) above; measured number below the stated range.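

In this assay hydrogen in place of (2-carboxyethyl)carbonyl on an oxygen on an aromatic ring gives an at least 5.5-fold lower number from compound 2 to compound 3 (0.74 log units; beyond the scatter) and moves the series off its limit. Within the data shown here, this oxygen substituent therefore bears on the read-out, a point that the earlier compounds could not show. The full size of the step cannot be read, because compound 2 rests on a limit: the limit of > 300000 nM in this assay, at which 2 of the 3 values shown sit.

The compounds shown leave open whether the free hydroxy is needed or whether a smaller group on this oxygen, such as acetyl or methyl, would give a similar number.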